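Bromo to iodo on the shared core

This account rests on a few compounds, and the source may have more. Where it says the series, first, only, none or still open, it means among the compounds named here.

Among the compounds with values here, in a functional assay on K562 cells (Homo sapiens) for inhibition, read by trypan blue exclusion, with a stated time of 48 h (on this read-out lower numbers stand for stronger inhibition and higher numbers for weaker inhibition), compound 1 `NC(=O)c1cc(Br)ccc1NC(=O)/C=C/c1ccccc1Cl` gives 8100 nM as the only actual number in this small set. Compound 2 `NC(=O)c1cc(Br)ccc1NC(=O)/C=C/c1cccc(Br)c1` reads > 10000 nM and that reading is a limit of the assay, not a number (the limit of > 10000 nM in this assay, at which 1 of the 2 values shown sits). Compound 1 therefore has no neighbour with a true number to be ranked against.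

Compound 3 `NC(=O)c1cc(I)ccc1NC(=O)/C=C/c1ccccc1Cl` keeps the 2-chlorophenyl group of compound 1 and changes one substituent (iodo in place of bromo on an aromatic carbon): iodo in place of bromo on an aromatic carbon, meta to a carbamoyl group and para to a large group. Within the data shown here, the one measured step (an at least 1.2-fold higher number from compound 1 to compound 2 (0.09 log units; that floor lies within the scatter)) has a floor within the scatter. It replaces 2-chlorophenyl with 3-bromophenyl on the chain and leaves the bromo untouched, so it bears on this change only indirectly. Among the measured compounds shown here, no measured step alters the bromo itself.

No step beyond the scatter is therefore expected in this assay, with compound 1 at 8100 nM as the anchor. The expected change (a 1.1-fold lower number from compound 1 to compound 3 (0.03 log units; within the scatter)) stays within the scatter. Compound 3 is estimated at 7500 nM with an expected range of 3500 nM to 14000 nM in this read-out.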

Compound 3, half-maximal inhibitory concentration: 1200 nM
Estimate against measurement, compound 3: 6.3-fold (0.80 log units) above, and the stated range ends above it.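

In this assay, within the data shown here, the position meta to a carbamoyl group and para to a large group is the first place in this set where one change gives a step beyond the scatter (a 6.8-fold lower number from compound 1 to compound 3 (0.83 log units; beyond the scatter)). Among these compounds, compound 2 reads > 10000 nM, which is a limit of the assay and not a number, and its bromo is unchanged, so the earlier compounds gave no reading on this position. Bromo and iodo each count as one heavy atom, with no ring, no hydrogen-bond donors or acceptors and no net charge, so those counts do not separate the two groups, and nothing measured in this set accounts for the step.

As far as these compounds go, whether iodo in place of bromo gives a comparable step with the 3-bromophenyl group of compound 2 on the chain remains open. Also open, from the compounds shown here alone, is how an amine, a methoxy group or a nitrile at this aromatic carbon would read against the bromo of compound 1 and the iodo of compound 3.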